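Pyrazole ureas and an amide: cell tolerance notes

The compounds below may be only part of what the source reports. "The series", "measured", "known", "first", "only" and "open" are said of these compounds alone.

Measured so far:
compound 1 `O=C(Nc1cccc(-n2cc(-c3ccncc3)c(-c3ccc(Cl)c(O)c3)n2)c1)Nc1ccc(Cl)c(Cl)c1` in a functional assay on CCRF-CEM cells (Homo sapiens) for inhibition, read by sulforhodamine B assay, with a stated time of 48 h; a lower number here means that less compound is tolerated, a higher number that more compound is tolerated: > 32500 nM
compound 2 `COc1cc(-c2nn(-c3cccc(NC(=O)c4ccc(Cl)c(C(F)(F)F)c4)c3)cc2-c2ccncc2)ccc1Cl` in this assay: > 32500 nM
compound 3 `O=C(Nc1cccc(-n2cc(-c3ccncc3)c(-c3ccc(Cl)c(O)c3)n2)c1)Nc1cc(C(F)(F)F)cc(C(F)(F)F)c1` in this assay: > 50000 nM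

Going by the values given here, every value so far is a limit of the assay rather than a number. Compound 1 stands at the limit of > 32500 nM in this assay, at which 2 of the 3 values shown sit. Compound 2 sits at that same limit. Compound 3 sits at the limit of > 50000 nM in this assay, at which 1 of the 3 values shown sits. Among the compounds with values here, no step between two measured compounds can be drawn, and the three limits show no order among them.

The next compound, compound 4 `O=C(Nc1cccc(-n2cc(-c3ccncc3)c(-c3ccc(Cl)c(O)c3)n2)c1)Nc1ccc(Cl)c(C(F)(F)F)c1`, differs from compound 1 by trifluoromethyl in place of chloro on an aromatic carbon. With compound 1 at > 32500 nM, no step beyond the scatter is expected in this assay, in either direction, and another limit is the likeliest outcome. Compound 4 is expected near 40000 nM, with a range from 15000 nM to 100000 nM, the expected step being a step that the limit leaves unreadable from compound 1 to compound 4.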

Compound 4, concentration lethal to 50% of the cells: > 32500 nM
Compound 4: no number, only a limit; the forecaster's own chance of this, stated with the estimate: 80%; the middle value is on the limit's open side.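

Compound 4 stands at the same limit as compound 1, so no step can be read between these two compounds: the limit of > 32500 nM in this assay, at which 3 of the 4 values shown sit.

The compounds shown leave open where any true value lies, and whether trifluoromethyl in place of chloro changes it.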